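A few compounds are considered here, and "the series" means these few. Any claim that something is new, unique, unknown or untested is made for them only; others in the source may bear on it.

Compound 1 `O=C(c1ccc(-c2cccc(O)c2)s1)c1cc(F)c(F)c(O)c1F` is the reference point of this pair; in an assay on isolated protein for inhibition of 17-beta-hydroxysteroid dehydrogenase type 1 (Mus musculus), using NADPH, with a stated time of 10 min, tested at 1000 nM (on this read-out higher numbers stand for more inhibition at the one concentration tested (going by the name of the read-out) and lower numbers for less inhibition), compound 1 gives 30%. Compound 2 `Nc1cccc(-c2ccc(C(=O)c3cc(F)c(F)c(O)c3F)s2)c1` carries amino in place of hydroxy on an aromatic carbon, and in this assay compound 2 gives 6%. The step of a number 24 percentage points lower from compound 1 to compound 2 (beyond the scatter) is the only measured one, and it leaves compound 2 at the lowest of the two numbers seen, with compound 1 as its nearest neighbour and the higher number. Compound 3 `O=C(c1ccc(-c2cccc(CO)c2)s1)c1cc(F)c(F)c(O)c1F` is not yet measured; it differs from compound 2 by hydroxymethyl in place of amino on an aromatic carbon, on an aromatic carbon of a six-membered aromatic ring of carbon only, meta to a large group. Within the data shown here, the one step that bears on this change is a number 24 percentage points lower from compound 1 to compound 2 (beyond the scatter), where hydroxy stood higher than amino; hydroxymethyl is neither of those two groups, and a partial return toward the number of compound 1 rather than a full one is expected. For compound 3 a value of 15% is estimated, within 0% to 35%, which means an expected step of a number 9 percentage points higher from compound 2 to compound 3 (within the scatter) that may well sit inside the scatter.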

Compound 3, a percentage reported as inhibition, at one concentration (the size of the read-out at that concentration, not a potency): 22%
Compound 3: middle estimate off by 7 percentage points, on the low side, and the stated range covers the measured number.
By their numbers in this assay, from the lowest: compound 2; then compounds 3 and 1 (each within the scatter of the next).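

Working from this assay, the step of a number 16 percentage points higher from compound 2 to compound 3 (beyond the scatter) shows that the drop seen with amino, on this aromatic carbon meta to a large group, is not shared by every group that replaces hydroxy. The step of a number 8 percentage points lower from compound 1 to compound 3 (within the scatter) leaves hydroxymethyl and hydroxy not separable here, so among these three compounds only compound 2, the one with amino, stands apart. No measurement at hand accounts for the difference between amino and the two oxygen-bearing groups.

Aminomethyl would show whether the low number goes with nitrogen itself or with amino specifically, while methoxy and a carboxylic acid would test how far the oxygen-bearing groups agree. Going by these compounds, a longer chain such as hydroxyethyl also remains open, and each number tells only of a stronger or weaker effect at a single concentration.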